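Propyl to Sulfamoyl Chain: Testing a Larger Side Chain

The compounds below may be only part of what the source reports. "The series", "measured", "known", "first", "only" and "open" are said of these compounds alone.

The measured compounds and their values:
compound 1 `Nc1nc2ccc(OC(F)(F)C(F)F)cc2s1` gives 8.5 mg/kg
compound 2 `Nc1nc2cc(OC(F)(F)F)ccc2s1` gives a limit, > 10 mg/kg
compound 3 `CCCn1c(=N)sc2cc(OC(F)(F)F)ccc21` gives 4.5 mg/kg

The read-out is a functional assay on the whole organism with Rattus norvegicus as the target; a lower number here means that less compound is needed, a higher number that more compound is needed for the effect. Compound 3 holds the lowest of the two numbers given, and the nearest number is that of compound 1, whose value is higher by an amount that falls inside the usual scatter of this kind of measurement. The value for compound 2 is a limit of the assay rather than a number, as the evidence shows (the limit of > 10 mg/kg in this assay, at which 1 of the 3 values shown sits).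

Compound 4 `CN(C)S(=O)(=O)CCn1c(=N)sc2cc(OC(F)(F)F)ccc21` is not yet measured. It differs from compound 3 in one place: dimethylsulfamoyl in place of methyl on a saturated chain carbon, two bonds along the chain from an aromatic nitrogen. Going by the values given here, no step between two measured compounds speaks to this kind of change, so nothing measured here tells how the assay will answer to it.

Compound 4 is therefore expected to land close to compound 3, with the step of a 1.3-fold higher number from compound 3 to compound 4 (0.12 log units; within the scatter) estimated to stay within the scatter or at most slightly beyond it toward a higher dose. The estimate for compound 4 is 6 mg/kg, expected to fall between 2.5 mg/kg and 15 mg/kg.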

Compound 4, dose for half-maximal effect: > 10 mg/kg
Compound 4 was reported as a limit (the forecaster's own chance of this, stated with the estimate: 25%); at least 1.6-fold (0.22 log units) between middle value and limit.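

Going by these compounds alone, this is the first step that reads a change at this place: on a saturated chain carbon, two bonds along the chain from an aromatic nitrogen, dimethylsulfamoyl in place of methyl gives an at least 2.2-fold higher number from compound 3 to compound 4 (0.34 log units; beyond the scatter) in this assay. The value of compound 4 is a limit of the assay and not a number, so the step has a known lower end but no known size: the limit of > 10 mg/kg in this assay, at which 2 of the 4 values shown sit. The position is therefore not indifferent to what its chain carries, since more compound is needed once this larger group enters.

This one step leaves open whether the extra size or the new sulfur, nitrogen and oxygen atoms make the difference. A longer plain carbon chain such as butyl, or a hydroxyl or an amine at the same place, could help tell these apart.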